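A few compounds are considered here, and "the series" means these few. Any claim that something is new, unique, unknown or untested is made for them only; others in the source may bear on it.

Of the compounds shown here, three built on one shared core have been tested in a functional assay on HepG2 cells (Homo sapiens) for inhibition, read by MTT assay, with a stated time of 72 h; on this read-out lower numbers stand for stronger inhibition and higher numbers for weaker inhibition. Compound 1 `COc1cccc(-n2cc(COc3cccc(NC(=O)Nc4ccc(Cl)c(C(F)(F)F)c4)c3)nn2)c1` gives 1310 nM in this assay. Compound 2 `N#Cc1ccccc1-n1cc(COc2cccc(NC(=O)Nc3ccc(Cl)c(C(F)(F)F)c3)c2)nn1` gives 1970 nM, and compound 3 `CCc1ccccc1-n1cc(COc2cccc(NC(=O)Nc3ccc(Cl)c(C(F)(F)F)c3)c2)nn1` gives 3530 nM. Among these three numbers compound 2 holds the second highest; its nearest neighbour is compound 1 and its furthest is compound 3, and both of those gaps fall within the scatter. The unmeasured compound 4 `O=C(Nc1cccc(OCc2cn(-c3ccc(I)cc3)nn2)c1)Nc1ccc(Cl)c(C(F)(F)F)c1` differs from compound 2 at a single place (4-iodophenyl in place of 2-cyanophenyl on an aromatic nitrogen). Going by the values given here, the steps that bear on this change all alter the same phenyl group on an aromatic nitrogen: a 1.5-fold higher number from compound 1 to compound 2 (0.18 log units; within the scatter), a 1.8-fold higher number from compound 2 to compound 3 (0.25 log units; within the scatter) and a 2.7-fold higher number from compound 1 to compound 3 (0.43 log units; beyond the scatter). Only the last of these reaches beyond the scatter, and even that one is modest. Exchanging one phenyl for another at this position is therefore expected to move this assay little, if at all, and the step is estimated as a 1.0-fold higher number from compound 2 to compound 4 (0.01 log units; within the scatter). Compound 4 is expected to give about 2000 nM, with a range from 900 nM to 4500 nM.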

Compound 4, half-maximal inhibitory concentration: 2690 nM
The estimate for compound 4 lay 1.3-fold (0.13 log units) below the measured number, within the range that was stated.
By their numbers in this assay, from the lowest: compounds 1, 2, 4 and 3 (each within the scatter of the next, the first and the last beyond it).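

In this assay, a phenyl bearing iodine fits this place on the ring nitrogen about as well as the 2-cyanophenyl and 2-ethylphenyl groups: the steps from both stay within the scatter (a 1.4-fold higher number from compound 2 to compound 4 (0.14 log units; within the scatter); a 1.3-fold lower number from compound 3 to compound 4 (0.12 log units; within the scatter)). The 3-methoxyphenyl comparison is the only one that passes the scatter, and only modestly (a 2.1-fold higher number from compound 1 to compound 4 (0.31 log units; beyond the scatter)), so compound 1 stands apart from compound 4 but not from compound 2. Nothing measured here gives a reason for these small steps.

No group appears here at two different places on the phenyl, so the effect of the group and the effect of where it sits cannot be separated. All the groups shown at this place are substituted phenyls, which leaves open how a phenyl carrying an amine or a carboxylic acid, or a longer alkyl chain in place of the ring, would behave in this assay.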